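A few compounds are considered here, and "the series" means these few. Any claim that something is new, unique, unknown or untested is made for them only; others in the source may bear on it.

Working notes on the aryl group of the anilide in this series. In an ADME assay on MT4 cells (Homo sapiens) for cytotoxicity, read by MTT assay, with a stated time of 5 days (on this read-out lower numbers stand for higher toxicity in this test and higher numbers for lower toxicity in this test), compound 1 `COc1cc2nc([S+]([O-])CC(=O)Nc3ccc(Cl)cc3)nc(Nc3c(Cl)cc(/C=C/C#N)cc3Cl)c2cc1OC` gives 14400 nM as a measured number. Compound 2 `COc1cc2nc([S+]([O-])CC(=O)Nc3ccc(C#N)cc3)nc(Nc3c(Cl)cc(/C=C/C#N)cc3Cl)c2cc1OC` stands at >= 188000 nM as a limit, not a number. Compound 3 `COc1cc2nc([S+]([O-])CC(=O)Nc3ccc(S(N)(=O)=O)cc3)nc(Nc3c(Cl)cc(/C=C/C#N)cc3Cl)c2cc1OC` stands at > 189000 nM as a limit too, and no number is available for it.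

Compound 4 `COc1cc2nc([S+]([O-])CC(=O)Nc3cc([N+](=O)[O-])ccc3F)nc(Nc3c(Cl)cc(/C=C/C#N)cc3Cl)c2cc1OC` carries 2-fluoro-5-nitrophenyl in place of 4-sulfamoylphenyl on an amide-type nitrogen is the full count of that exchange.

Among the compounds with values here, no measured step makes this exact exchange, but three concern the same aryl group. Cyano in place of chloro gives an at least 13-fold higher number from compound 1 to compound 2 (1.11 log units; beyond the scatter) as its result. Sulfamoyl in place of chloro gives an at least 13-fold higher number from compound 1 to compound 3 (1.11 log units; beyond the scatter) as its result. Sulfamoyl in place of cyano gives a step that the two limits leave unreadable from compound 2 to compound 3 as its result.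

Compound 4 has neither the sulfamoyl substituent of compound 3 nor the cyano substituent of compound 2, so it is expected to fall back toward compound 1 at 14400 nM without fully reaching it. In this assay the expected change is an at least 4.7-fold lower number from compound 3 to compound 4 (0.67 log units; beyond the scatter) in the direction of a lower number, and its size stays loose while the starting point is a limit. For compound 4 the estimate is 40000 nM with an expected range of 9000 nM to 190000 nM in this test.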

Compound 4, half-maximal cytotoxic concentration: > 194000 nM
Compound 4: no number, only a limit; the forecaster's own chance of this, stated with the estimate: 35%; middle value at least 4.8-fold (0.68 log units) away from the limit.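

In this assay, the exchange of 4-chlorophenyl for 2-fluoro-5-nitrophenyl on the amide-type nitrogen gives an at least 13-fold higher number from compound 1 to compound 4 (1.12 log units; beyond the scatter). The shift to a higher number therefore does not depend on the cyano group of compound 2 or the sulfamoyl group of compound 3: compound 4 carries neither, yet it stands with them, and compound 1 remains the only one of the four with a measured number rather than a limit. Compound 4 ends at a limit too, so its steps to compound 2 and compound 3 cannot be read, nor can the step between those two: the limit of > 194000 nM in this assay, at which 1 of the 4 values shown sits.

As far as these compounds go, how far the true values of compound 2, compound 3 and compound 4 lie past their limits stays open, and so does any order among them. Also open, from the compounds shown here alone, is whether the lower number of compound 1 belongs to chloro alone, or whether a bromo, methyl, amine or carboxylic acid group on the same aryl ring would give a measured number in this assay or another limit.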